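This account rests on a few compounds, and the source may have more. Where it says the series, first, only, none or still open, it means among the compounds named here.

Compound 3 `Cn1cc(NC(=O)c2ccncc2Nc2cc(-c3ccc4ccn(C)c4c3)c3nccnc3c2)cn1` carries a 1-methyl-1H-pyrazol-4-yl group on an amide-type nitrogen of the shared core. In an assay on lysate for inhibition of 6-phosphofructo-2-kinase/fructose-2,6-bisphosphatase 3 (Homo sapiens), with stated times of 0.5 min and 45 min (a higher number here means a weaker inhibitor, a lower number a stronger inhibitor), compound 3 gives 26500 nM, the highest of the two numbers available, with compound 1 `CN1CCC(NS(=O)(=O)c2ccccc2Nc2cc(-c3ccc4ccn(C)c4c3)c3nccnc3c2)C1` as its nearest neighbour: in this assay compound 1 gives 3160 nM. Compound 2 `Cn1ccc2ccc(-c3cc(Nc4ccccc4S(=O)(=O)NCC4CCOCC4)cc4nccnc34)cc21` reaches only a limit in this assay, > 100000 nM, and no number is known for it.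

Compound 4 `CN1CC(NC(=O)c2ccncc2Nc2cc(-c3ccc4ccn(C)c4c3)c3nccnc3c2)CCC1=O` is not yet measured. Compared with compound 3 it shows (1-methyl-6-oxopiperidin-3-yl in place of 1-methyl-1H-pyrazol-4-yl on an amide-type nitrogen).

Among the compounds with values here, the one measured step, an at least 31-fold higher number from compound 1 to compound 2 (1.50 log units; beyond the scatter), concerns a sulfonamide nitrogen rather than an amide-type nitrogen, and its only evidence is the limit of > 100000 nM in this assay, at which 1 of the 3 values shown sits; it therefore bears on the present change only loosely. It does show that exchanging one ring-bearing substituent for another at a nitrogen of this kind can move the number strongly in the weaker direction, and compound 3 already stands high. A moderate weakening is therefore expected, a 1.5-fold higher number from compound 3 to compound 4 (0.18 log units; within the scatter), with a real chance that only a limit is reported.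

For compound 4 the estimate in this assay is 40000 nM, expected to lie between 12000 nM and 130000 nM.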

Compound 4, half-maximal inhibitory concentration: 96500 nM
Compound 4: the middle estimate sits 2.4-fold (0.38 log units) below what was measured, and the stated range covers the measured number.
By their numbers in this assay, from the lowest: compound 1; then compound 3; then compound 4. At a limit, above all of these: compound 2.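

Within the data shown here, this is the first step read at the amide-type nitrogen itself, and it shows that the group there matters on its own: with 1-methyl-6-oxopiperidin-3-yl in place of 1-methyl-1H-pyrazol-4-yl, this assay records a 3.6-fold higher number from compound 3 to compound 4 (0.56 log units; beyond the scatter). The earlier compounds shown here offered only a step at a sulfonamide nitrogen, and the new step runs the same way, towards a weaker inhibitor, although two steps at two different nitrogens make no rule. At this weak end of the scale, compound 2 remains a limit and not a number: the limit of > 100000 nM in this assay, at which 1 of the 4 values shown sits.

The change swaps a five-membered aromatic ring for a six-membered non-aromatic ring and also brings in a ring carbonyl, and the compounds shown cannot tell which of these carries the step; 1-methylpiperidin-3-yl on the same nitrogen, which keeps the non-aromatic ring without the carbonyl, would separate the two. Also open, as far as these compounds go, is how a small group such as methyl, or a basic amine such as 1-methylpyrrolidin-3-yl, would read on this amide-type nitrogen.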